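The source may report more compounds than this note shows. Statements on the series, on what has been measured and on what is new or still open speak of the compounds shown alone.

In a functional assay on SEM cells (Homo sapiens) for cytotoxicity, with a stated time of 72 h (a lower number here means that less compound is needed, a higher number that more compound is needed for the effect), the measured compounds and their values stand as follows.

Compound 1, `C=C[C@@](C)(/C=C/c1ccc(OC)cc1)CCC=C(C)C`, gives > 36600 nM, which is a limit of the assay and not a number.
Compound 2, `C=C[C@@](C)(/C=C/c1ccc(O)cc1)CC/C=C(\C)C=O`, gives > 36600 nM, which is again a limit of the assay.

Among the compounds with values here, compound 1 therefore stands at the limit of this assay rather than at a measured number, and it shares this position with the one other value shown, as recorded by the limit of > 36600 nM in this assay, at which 2 of the 2 values shown sit. Within the data shown here, no step between measured compounds that differ in a single place is available, so the two values show only that neither compound 1 nor compound 2 reaches a half-maximal effect within the range this assay covers.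

Compound 3, `C=C[C@@](C)(/C=C/c1ccc(Nc2ccc(Cl)c(Cl)c2)cc1)CCC=C(C)C`, has not yet been measured in this assay. Its difference from compound 1 is (3,4-dichlorophenyl)amino in place of methoxy on an aromatic carbon. Among the measured compounds shown here, with compound 1 sitting at > 36600 nM, there is no measured step from which to scale this change. For compound 3 the step of an at least 1.8-fold lower number from compound 1 to compound 3 (0.26 log units; that floor lies within the scatter) is expected to be modest, a move toward a number rather than a limit, and not clearly beyond the scatter. Compound 3 is accordingly estimated at 20000 nM, with a range from 5000 nM to 60000 nM, and a real chance that this assay again returns only a limit.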

Compound 3, half-maximal effective concentration: > 36600 nM
Compound 3: no number, only a limit (the forecaster's own chance of this, stated with the estimate: 50%); at least 1.8-fold (0.26 log units) between middle value and limit.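

In this assay compound 3 gives > 36600 nM, which is a limit of the assay and not a number. Compound 1 also stands at a limit, so no step from compound 1 to compound 3 can be read: the limit of > 36600 nM in this assay, at which 3 of the 3 values shown sit.

The compounds shown leave open which change to the shared core, if any, would give a measured half-maximal effect in this assay.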